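Macrocycle series: 4-carboxyphenoxy replaces the hydroxycarbamoyl arm

The compounds below may be only part of what the source reports. "The series", "measured", "known", "first", "only" and "open" are said of these compounds alone.

Measured so far in a functional assay on HCT-116 cells (Homo sapiens) for antiproliferative activity, read by MTT assay, with a stated time of 72 h; on this read-out higher numbers stand for weaker inhibition and lower numbers for stronger inhibition:
compound 1 `O=C(CCCCCOc1ccc2cc1COC/C=C/COCc1cccc(c1)-c1ccnc(n1)N2)NO`: 2560 nM
compound 2 `O=C(NO)c1cccc(NCCOc2ccc3cc2COC/C=C/COCc2cccc(c2)-c2ccnc(n2)N3)c1`: 2010 nM
compound 3 `O=C(NO)c1ccc(NCCOc2ccc3cc2COC/C=C/COCc2cccc(c2)-c2ccnc(n2)N3)cc1`: 3200 nM

All three share one macrocyclic core and differ only in the arm carrying the hydroxycarbamoyl group. Compound 3 gives the highest number of the three, but its nearest neighbour is compound 1 with a 1.3-fold higher number from compound 1 to compound 3 (0.10 log units; within the scatter), and against compound 2 the step is a 1.6-fold higher number from compound 2 to compound 3 (0.20 log units; within the scatter); both lie within the scatter, as does a 1.3-fold lower number from compound 1 to compound 2 (0.11 log units; within the scatter). On the numbers shown, the three compounds cannot be ranked.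

Compound 4 `O=C(O)c1ccc(OCCOc2ccc3cc2COC/C=C/COCc2cccc(c2)-c2ccnc(n2)N3)cc1` is not yet measured. It differs from compound 3 thus: 4-carboxyphenoxy in place of (4-(hydroxycarbamoyl)phenyl)amino on a saturated chain carbon, two bonds along the chain from an oxygen on an aromatic ring.

For the measured compounds named here, none of the measured steps bears on this change: each of them moves or re-attaches the hydroxycarbamoyl group, and none removes it. Because the measured steps are all within the scatter, there is no measured guidance on the size of this step. Since the group common to all three measured compounds leaves in compound 4, a weaker result is expected, and the estimate is uncertain. Compound 4 is expected to give about 15000 nM in this assay, within 4000 nM to 60000 nM, which would be a step of a 4.7-fold higher number from compound 3 to compound 4 (0.67 log units; beyond the scatter).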

Compound 4, half-maximal inhibitory concentration: 29700 nM
Estimate against measurement, compound 4: 2.0-fold (0.30 log units) below; the measured number falls inside the stated range.
By their numbers in this assay, from the lowest: compounds 2, 1 and 3 (each within the scatter of the next); then compound 4.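

In this assay, swapping the arm on a saturated chain carbon, two bonds along the chain from an oxygen on an aromatic ring, for 4-carboxyphenoxy is the only change shown that moves the number beyond the scatter (a 9.3-fold higher number from compound 3 to compound 4 (0.97 log units; beyond the scatter); a 15-fold higher number from compound 2 to compound 4 (1.17 log units; beyond the scatter); a 12-fold higher number from compound 1 to compound 4 (1.06 log units; beyond the scatter)). The three hydroxycarbamoyl arms could not be told apart, whereas compound 4 separates from each of them and is the weakest of the four. No measurement shown accounts for the size of these steps.

From the compounds shown here alone, the step from compound 3 to compound 4 exchanges both the hydroxycarbamoyl group for a carboxylic acid and the amine nitrogen for an ether oxygen, so the share of each exchange stays open. A 4-(hydroxycarbamoyl)phenoxy arm or a (4-carboxyphenyl)amino arm would separate the two.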